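The compounds below may be only part of what the source reports. "The series", "measured", "known", "first", "only" and "open" are said of these compounds alone.

In a functional assay on NCI-H23 cells (Homo sapiens) for inhibition, read by sulforhodamine B assay, with a stated time of 48 h (on this read-out higher numbers stand for weaker inhibition of growth and lower numbers for stronger inhibition of growth), compound 2 `COc1cc(-c2nn(-c3cccc(NC(=O)Nc4ccc(Cl)c(Cl)c4)c3)cc2-c2ccncc2)ccc1Cl` gives 5190 nM. Compound 1 `COc1cc(-c2nn(-c3cccc(NC(=O)Nc4cc(C(F)(F)F)cc(C(F)(F)F)c4)c3)cc2-c2ccncc2)ccc1Cl` gives 3340 nM, and compound 3 `O=C(Nc1cccc(-n2cc(-c3ccncc3)c(-c3ccc(Cl)c(O)c3)n2)c1)Nc1ccc(Cl)c(Cl)c1` gives 29100 nM. Among the compounds with values here, compound 2 thus stands second highest of the three numbers, within the scatter of compound 1 and well apart from compound 3; the one measured step, a 5.6-fold higher number from compound 2 to compound 3 (0.75 log units; beyond the scatter), goes with hydrogen in place of methyl on an oxygen on an aromatic ring. Compound 4 `COc1cc(-c2nn(-c3cccc(NC(=O)c4ccc(Cl)c(C(F)(F)F)c4)c3)cc2-c2ccncc2)ccc1Cl` differs from compound 2 by 4-chloro-3-(trifluoromethyl)phenyl in place of (3,4-dichlorophenyl)amino on a carbonyl carbon. Within the data shown here, no measured step covers this change, and the step to compound 3 concerns another part of the shared core. Compounds 1 and 2 show that a different substituted phenyl at this end changes little. Compound 4 is therefore estimated at 5000 nM, from 1500 nM to 17000 nM. The expected step is a 1.0-fold lower number from compound 2 to compound 4 (0.02 log units; within the scatter).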

Compound 4, concentration for total growth inhibition: > 32500 nM
Compound 4: a limit, no number (the forecaster's own chance of this, stated with the estimate: 5%); middle value at least 6.5-fold (0.81 log units) from the limit.
By their numbers in this assay, from the lowest: compounds 1 and 2 (each within the scatter of the next); then compound 3. At a limit, above all of these: compound 4.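

Compounds 1 and 2 sit within the scatter of each other, but both keep an amino nitrogen on this carbonyl carbon. Putting 4-chloro-3-(trifluoromethyl)phenyl in place of (3,4-dichlorophenyl)amino gives an at least 6.2-fold higher number from compound 2 to compound 4 (0.79 log units; beyond the scatter), so this position is not indifferent to change. Compound 4 stands at a limit of the assay, not at a number: the limit of > 32500 nM in this assay, at which 1 of the 4 values shown sits.

This single swap removes the amino nitrogen and changes the ring substituents together, so the step cannot be assigned to either alone. A [4-chloro-3-(trifluoromethyl)phenyl]amino group on the same carbonyl carbon would separate the two.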